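This account rests on a few compounds, and the source may have more. Where it says the series, first, only, none or still open, it means among the compounds named here.

In an assay on microsomes from brain for inhibition of Fatty-acid amide hydrolase 1 (Rattus norvegicus), read by fluorescence and HPLC, with a stated time of 60 min (a lower number here means a stronger inhibitor, a higher number a weaker inhibitor), compound 3 `CC(Oc1ccc(Oc2ccc(Cl)cc2)cc1)C(=O)Cn1nnc(-c2ccccc2)n1` gives 51 nM, the second-highest of three numbers. Its nearest neighbour is compound 2 `CCCCCCCCc1ccc(OC(C)C(=O)Cn2nnc(-c3ccccc3)n2)cc1`, which gives 24 nM; the furthest is compound 1 `CCCCCCCCc1ccc(OCC(=O)Cn2nnc(-c3ccc(S(=O)(=O)N(C)C)cc3)n2)cc1`, which gives 590 nM. Compound 4 `CC(Oc1ccc(-c2ccccc2)cc1)C(=O)Cn1nnc(-c2ccccc2)n1` differs from compound 3 by phenyl in place of 4-chlorophenoxy on an aromatic carbon. Among the compounds with values here, the only measured step that touches the same position is a 2.1-fold higher number from compound 2 to compound 3 (0.33 log units; beyond the scatter), a modest change. Within the data shown here, no measured pair shows a phenyl at that place, so the direction is not settled; taking the change from compound 2 to compound 3 as the nearest guide, a loss of similar or slightly larger size seems more likely than a gain. Compound 4 is therefore expected to give 100 nM, between 30 nM and 400 nM, which would mean a 2.0-fold higher number from compound 3 to compound 4 (0.29 log units; within the scatter).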

Compound 4, half-maximal inhibitory concentration: 15 nM
Estimate against measurement, compound 4: 6.7-fold (0.82 log units) above; measured number below the stated range.
By their numbers in this assay, from the lowest: compounds 4 and 2 (each within the scatter of the next); then compound 3; then compound 1.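

Phenyl on this aromatic carbon gives a lower number than 4-chlorophenoxy, with a 3.4-fold lower number from compound 3 to compound 4 (0.53 log units; beyond the scatter). Set against octyl, it shows a 1.6-fold lower number from compound 2 to compound 4 (0.20 log units; within the scatter), so the loss seen on going to 4-chlorophenoxy does not extend to every aromatic group at this place. The change removes the oxygen and the chlorine together, so this step cannot separate the two.

Going by these compounds, whether plain phenoxy or a 4-chlorophenyl group would stand with compound 3 or with compound 4 remains open. No evidence is available to explain the step.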